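This account rests on a few compounds, and the source may have more. Where it says the series, first, only, none or still open, it means among the compounds named here.

Four compounds were studied in a functional assay on the whole organism with Mus musculus as the target, in the maximal electroshock model; on this read-out higher numbers stand for an effect only at larger amounts of compound and lower numbers for an effect already at smaller amounts. Compound 1 `Clc1ccc(N2N=NCC2c2ccncc2)cc1` gives 257 mg/kg in this assay. Compound 2 `c1ccc(N2N=NCC2c2ccncc2)cc1` differs from compound 1 by a single change, (hydrogen in place of chloro on an aromatic carbon), and in this assay compound 2 gives 165 mg/kg. That change made a 1.6-fold lower number from compound 1 to compound 2 (0.19 log units; within the scatter), a step that stays inside the usual scatter of repeated measurements of this kind.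

Compound 3 `Clc1ccc(-n2nncc2-c2ccccn2)cc1` is built on a different core; the difference between the two cores is not broken down here. In this assay compound 3 gives 95.3 mg/kg. Its gap to compound 2 lies within the scatter, whereas its gap to compound 1 lies beyond it.

Compound 4 `c1ccc(-n2nncc2-c2ccccn2)cc1` stands to compound 3 as compound 2 stands to compound 1: it carries hydrogen in place of chloro on an aromatic carbon, the same change at the same kind of place. The change has been measured only once among these compounds, and that instance, the step from compound 1 to compound 2, was small. Among the measured compounds shown here, because the only measured instance made a 1.6-fold lower number from compound 1 to compound 2 (0.19 log units; within the scatter), a step of about the same size is expected here. The estimated step is a 1.5-fold lower number from compound 3 to compound 4 (0.19 log units; within the scatter), resting on that single precedent and on nothing else. Compound 4 is therefore estimated to give 62 mg/kg in this assay, with a plausible range from 32 mg/kg to 130 mg/kg.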

Compound 4, dose for half-maximal effect: 41.1 mg/kg
Compound 4: middle estimate off by 1.5-fold (0.18 log units), on the high side; measured number inside the range.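

In this assay, putting hydrogen in place of chloro on the aromatic carbon gave a 2.3-fold lower number from compound 3 to compound 4 (0.37 log units; beyond the scatter), and this step, unlike the earlier one on the other core, lies beyond the scatter. Set side by side, the two steps run in the same direction and cannot be told apart in size: the same change on two cores in this assay, a 1.6-fold lower number (0.19 log units; within the scatter) from compound 1 to compound 2 and a 2.3-fold lower number (0.37 log units; beyond the scatter) from compound 3 to compound 4, 1.5-fold (0.17 log units) apart, within the scatter of two such steps. On these two cores, then, the change carried over in direction and about in size, so the step measured on the first core was a usable guide to the second, but two instances do not show that the same would hold on a further core, that the core has no influence on the step, or why removing chloro goes with effects at smaller amounts.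

The compounds shown have only chloro or hydrogen at this place, para to a large group, so it stays open how a fluoro, a methyl, a methoxy or an amine there would compare with either of them. As far as these compounds go, it also stays open which feature of the difference between the two cores matters for the read-out, as that difference is not broken down into single changes here.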